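Swapping 2,5-dimethoxyphenyl for 3,4-dimethoxyphenyl in a cytotoxicity series

The source may report more compounds than this note shows. Statements on the series, on what has been measured and on what is new or still open speak of the compounds shown alone.

Compound 1 `COc1ccc(/C=C/C(=O)/C=C/c2cc3ccccc3nc2Oc2ccccc2)cc1OC` – > 10000 nM
Compound 2 `COc1ccc(OC)c(/C=C/C(=O)/C=C/c2cc3ccccc3nc2Oc2ccc(Br)cc2)c1` – > 10000 nM

In a functional assay on 4T1 cells (Mus musculus) for cytotoxicity, read by MTT assay, with a stated time of 48 h (on this read-out lower numbers stand for stronger inhibition and higher numbers for weaker inhibition), compound 1 gives > 10000 nM as a limit of the assay and not a number. In this assay compound 2 gives > 10000 nM as a limit too, so compound 2 has no number of its own.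

Compound 3 `COc1ccc(/C=C/C(=O)/C=C/c2cc3ccccc3nc2Oc2ccc(Br)cc2)cc1OC` has not yet been measured. It carries 3,4-dimethoxyphenyl in place of 2,5-dimethoxyphenyl on a double-bonded chain carbon bound to a double-bonded chain carbon and keeps everything else of compound 2.

Within the data shown here, compound 2 rests at the limit of > 10000 nM in this assay, at which 2 of the 2 values shown sit, and no measured pair shows what such a change does, so no step beyond the scatter is expected in this assay in either direction. The estimated move is a number no higher from compound 2 to compound 3 (the limit leaves the size open) and it remains a rough guess. For compound 3 the expected value is 10000 nM with an estimated range from 3000 nM to 30000 nM and a report as a limit alone would be no surprise.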

Compound 3, half-maximal inhibitory concentration: > 10000 nM
Compound 3 gave a limit, no number; the forecaster's own chance of this, stated with the estimate: 65%; the middle value lies on the limit itself.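

In this assay, among these compounds, compound 3 gives > 10000 nM, a limit and not a number, so no step from compound 1 or compound 2 to compound 3 can be read. The compounds shown leave open whether 3,4-dimethoxyphenyl in place of 2,5-dimethoxyphenyl, or bromo in place of hydrogen, changes cytotoxicity at all.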